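Removing the meta methoxy from the weak 3-methoxyphenyl analogue

The source may report more compounds than this note shows. Statements on the series, on what has been measured and on what is new or still open speak of the compounds shown alone.

Among the measured compounds shown here, compound 2 `C=CC[C@H]1C[C@]2([C@@H](C)Cc3cccc(OC)c3)OCOC2=CC1=O` is the weaker of the two measured members: in a functional assay on NCI-H460 cells (Homo sapiens) for antiproliferative activity, with a stated time of 72 h (a higher number here means a weaker inhibitor, a lower number a stronger inhibitor), compound 2 gives 10600 nM, the highest number recorded, while compound 1 `C=CC[C@H]1C[C@]2([C@@H](C)Cc3ccc(OC)cc3)OCOC2=CC1=O` gives 90 nM. For the measured compounds named here, the only measured step, a 120-fold higher number from compound 1 to compound 2 (2.07 log units; beyond the scatter), shows that replacing 4-methoxyphenyl by 3-methoxyphenyl on the chain carbon costs a great deal.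

Compound 3 `C=CC[C@H]1C[C@]2([C@@H](C)Cc3ccccc3)OCOC2=CC1=O` differs from compound 2 by hydrogen in place of methoxy on an aromatic carbon, so that a plain phenyl remains. Going by the values given here, no measured step tells directly what losing the methoxy does; the one step available, a 120-fold higher number from compound 1 to compound 2 (2.07 log units; beyond the scatter), says only that the methoxy in its 3-position is badly placed relative to its 4-position. Removing it could undo part of that loss without restoring what 4-methoxyphenyl supplied, so a recovery of modest to moderate size is expected, a 5.3-fold lower number from compound 2 to compound 3 (0.72 log units; beyond the scatter). For compound 3 the expected value in this assay is 2000 nM, within a range from 300 nM to 15000 nM.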

Compound 3, half-maximal inhibitory concentration: 9700 nM
Compound 3: middle estimate off by 4.9-fold (0.69 log units), on the low side, within the range that was stated.
By their numbers in this assay, from the lowest: compound 1; then compounds 3 and 2 (each within the scatter of the next).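

Replacing 3-methoxyphenyl by phenyl in this assay gives a 1.1-fold lower number from compound 2 to compound 3 (0.04 log units; within the scatter), so a methoxy in that place makes no difference that can be read. Taken from the other side, hydrogen in place of the methoxy of 4-methoxyphenyl gives a 110-fold higher number from compound 1 to compound 3 (2.03 log units; beyond the scatter), which ties the large gap in this set of three to 4-methoxyphenyl rather than to any penalty from 3-methoxyphenyl. No evidence is available that bears on the origin of this difference.

From the compounds shown here alone, it remains open whether 4-hydroxyphenyl, 4-fluorophenyl or 4-ethoxyphenyl in place of 4-methoxyphenyl would hold the number of compound 1 or fall back to that of compound 3. Also open, going by these compounds, is how 3,4-dimethoxyphenyl would read, with a methoxy in both places.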